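Replacing 2-methoxyphenyl with phenyl in the series

The source may hold more compounds than are shown below. What is called first, only, known or untested is meant among the compounds shown, and "the series" means these compounds.

In a functional assay on HCT-116 cells (Homo sapiens) for cytotoxicity, with a stated time of 48 h (on this read-out lower numbers stand for stronger inhibition and higher numbers for weaker inhibition), compound 2 (`COc1cc(OC)c(C(=O)/C=C/c2ccccc2OC)c(OC)c1`) gives 4200 nM and compound 3 (`COc1cccc(/C=C/C(=O)c2c(OC)cc(OC)cc2OC)c1`) gives 4300 nM, level within the scatter. Compound 1 (`COc1cc(O)c(C(=O)/C=C/c2ccc(F)cc2)c(OC)c1`) gives 12400 nM, a higher number than either, beyond the scatter, so compound 2 sits in the lower pair. Compound 4 (`COc1cc(OC)c(C(=O)/C=C/c2ccccc2)c(OC)c1`) has hydrogen in place of methoxy on an aromatic carbon, ortho to a large group: hydrogen in place of methoxy on an aromatic carbon. Among the measured compounds shown here, the only measured step bearing on this is a 1.0-fold higher number from compound 2 to compound 3 (0.01 log units; within the scatter), which stays within the scatter. For the measured compounds named here, it swaps 2-methoxyphenyl for 3-methoxyphenyl, and no measured step removes the methoxy, so the evidence is thin. The expected change is a 1.2-fold higher number from compound 2 to compound 4 (0.08 log units; within the scatter), with no step beyond the scatter anticipated. For compound 4 the estimate is 5000 nM, with an expected range of 2200 nM to 11000 nM.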

Compound 4, half-maximal inhibitory concentration: 6900 nM
Estimate against measurement, compound 4: 1.4-fold (0.14 log units) below, within the range that was stated.
By their numbers in this assay, from the lowest: compounds 2, 3, 4 and 1 (each within the scatter of the next, the first and the last beyond it).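

In this assay, among the compounds shown here, the methoxy is now removed directly for the first time: 2-methoxyphenyl to phenyl gives a small step (a 1.6-fold higher number from compound 2 to compound 4 (0.22 log units; within the scatter)), and 3-methoxyphenyl to phenyl gives a similar one (a 1.6-fold higher number from compound 3 to compound 4 (0.21 log units; within the scatter)). Both steps stay within the scatter, so among these compounds the methoxy is not shown to matter at either place, and hydrogen serves as well as methoxy on this read-out.

From the compounds shown here alone, whether an amine or a carboxylic acid at this place would move the number beyond the scatter remains open. Nothing at hand explains these numbers.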